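Sulfonamide series: aryl swap on the sulfonyl sulfur

This account rests on a few compounds, and the source may have more. Where it says the series, first, only, none or still open, it means among the compounds named here.

Compound 1 `O=C(O)CCC/C=C\CC1=CCC[C@@H]1NS(=O)(=O)c1ccc(F)cc1` and compound 2 `O=C(O)CCC/C=C\CC1=CCC[C@@H]1NS(=O)(=O)c1ccccc1[N+](=O)[O-]` share one core and differ only in the aryl group on the sulfonyl sulfur. Among the measured compounds shown here, in a functional assay on a cell-free system (plasma) for inhibition of thromboxane A2 receptor (Homo sapiens), read by turbidimetry (a higher number here means a weaker inhibitor, a lower number a stronger inhibitor), compound 1 gives 4400 nM; 4400 nM (2 entries), and compound 2 gives 680 nM as its only number; one further entry for compound 2 carries no number. For the measured compounds named here, no computed step links the two. Compound 3 `Cc1ccc(S(=O)(=O)N[C@H]2CCC=C2C/C=C\CCCC(=O)O)cc1` carries 4-methylphenyl in place of 2-nitrophenyl on a sulfonyl sulfur. With a para-substituted ring again, as in compound 1 at 4400 nM; 4400 nM (2 entries), the step from compound 2 is expected to move towards weaker inhibition, estimated as a 3.7-fold higher number from compound 2 to compound 3 (0.57 log units; beyond the scatter). Compound 3 is expected at 2500 nM, between 700 nM and 8000 nM.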

Compound 3, half-maximal inhibitory concentration: 250 nM
The estimate for compound 3 lay 10-fold (1.00 log units) above the measured number; the whole stated range lies above it.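

In this assay, 4-methylphenyl in place of 2-nitrophenyl on the sulfonyl sulfur gives a 2.7-fold lower number from compound 2 to compound 3 (0.43 log units; beyond the scatter), so the nitro group is not required for inhibition at this position. A ring of carbon only, with no hydrogen-bond acceptors, serves here, while the sulfonyl aryl group of compound 1 stands at 4400 nM; 4400 nM (2 entries), so the substituent itself matters and not only where it sits. Nothing at hand explains the step. Open, from the compounds shown here alone, is how a 4-methoxyphenyl or 4-aminophenyl group on the sulfonyl sulfur would read in this assay.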